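This account rests on a few compounds, and the source may have more. Where it says the series, first, only, none or still open, it means among the compounds named here.

Four compounds share one core and differ only in the halogen that sits on a six-membered aromatic ring of carbon only. Compound 1 `Fc1cccc(NC(=S)OCCc2ccccn2)c1` carries a fluoro group and compound 2 `S=C(Nc1cccc(Cl)c1)OCCc1ccccn1` a chloro group in the same place. Compound 3 `Fc1ccc(NC(=S)OCCc2ccccn2)cc1` and compound 4 `S=C(Nc1ccc(Cl)cc1)OCCc1ccccn1` form a second pair; compound 3 is built from the same atoms as compound 1, joined differently, and the difference between the two cores is not broken down here.

The read-out is an ADME assay on MT4 cells (Homo sapiens) for cytotoxicity, read by MTT assay; a higher number here means that more compound is tolerated, a lower number that less compound is tolerated. Compound 1 reaches only a limit of the assay, not a number, at >= 100000 nM. Compound 2 gives 47000 nM. The change between them is chloro in place of fluoro on an aromatic carbon, and it produced an at least 2.1-fold lower number from compound 1 to compound 2 (0.32 log units; beyond the scatter). Only a bound can be given for that step because compound 1 sits at the limit of >= 100000 nM in this assay, at which 1 of the 3 values shown sits.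

Compound 3 likewise reaches only a limit of the assay, at > 100000 nM, and this is the limit of > 100000 nM in this assay, at which 1 of the 3 values shown sits. The change to compound 4 is chloro in place of fluoro on an aromatic carbon. Going by the values given here, it is the same kind of change as the one from compound 1 to compound 2, not the same, since the chloro group in compound 4 stands para to a large group while in compound 2 it stands meta to a large group.

Compound 4 is expected to tolerate less than compound 3, by an at least 2.0-fold lower number from compound 3 to compound 4 (0.30 log units; that floor lies within the scatter), because the same kind of change gave an at least 2.1-fold lower number from compound 1 to compound 2 (0.32 log units; beyond the scatter). The estimate for compound 4 in this assay is therefore 50000 nM, between 25000 nM and 100000 nM.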

Compound 4, half-maximal cytotoxic concentration: 52000 nM
The estimate for compound 4 lay 1.0-fold (0.02 log units) below the measured number; the measured number falls inside the stated range.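

In this assay, chloro in place of fluoro on an aromatic carbon again goes with a lower number, an at least 1.9-fold lower number from compound 3 to compound 4 (0.28 log units; that floor lies within the scatter), so the direction seen on the core of compound 1 also appears on the core of compound 3, although the smallest step this allows is not clearly larger than the usual scatter of repeated measurements. The two cores cannot show whether the change has the same size on each, and no shared size for it can be given: the same change on two cores in this assay, an at least 2.1-fold lower number (0.32 log units; beyond the scatter) from compound 1 to compound 2 and an at least 1.9-fold lower number (0.28 log units; that floor lies within the scatter) from compound 3 to compound 4; the limit leaves it open whether they differ. The step from the fluoro to the chloro compound can be given only as a floor, and its true size stays unknown, because compound 3 reaches a limit of the assay rather than a number: the limit of > 100000 nM in this assay, at which 1 of the 4 values shown sits.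

The compounds shown compare only fluoro and chloro, so they leave open whether a larger halogen such as bromo, or a different group such as methoxy or an amine, would follow the same direction on either core. They also leave open how far the fluoro compounds lie from their limits, and whether a longer chain in the shared core would change the size of the step.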